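A few compounds are considered here, and "the series" means these few. Any claim that something is new, unique, unknown or untested is made for them only; others in the source may bear on it.

Compound 1 `CCOC(=O)CC(=O)N1CCSC1COc1ccccc1OC` holds the lowest of the three numbers in a functional assay on the whole organism for inhibition, with Cavia porcellus as the target (on this read-out lower numbers stand for an effect already at smaller amounts and higher numbers for an effect only at larger amounts of compound), where compound 1 gives 21 mg/kg, though its steps to both neighbours stay within the scatter. Compound 2 `COc1ccccc1OCC1SCCN1C(=O)C[S+](C)[O-]` gives 25 mg/kg and compound 3 `COc1ccccc1OCC1SCCN1C(=O)CNC(C)=O` gives 40 mg/kg; the steps of a 1.2-fold higher number from compound 1 to compound 2 (0.08 log units; within the scatter) and a 1.9-fold higher number from compound 1 to compound 3 (0.28 log units; within the scatter) lie within the scatter, as does a 1.6-fold higher number from compound 2 to compound 3 (0.20 log units; within the scatter). Compound 4 `CCN(CC)CCNC(=O)CC(=O)N1CCSC1COc1ccccc1OC` differs from compound 1 by (2-(diethylamino)ethyl)amino in place of ethoxy on a carbonyl carbon. For the measured compounds named here, no measured step touches the carbonyl carbon in this way; all three reshape the saturated chain carbon bound to the carbonyl carbon, and none moves the number beyond the scatter. On that basis the step of no change at the digits printed from compound 1 to compound 4 (within the scatter) is expected to remain within the scatter. Compound 4 is therefore estimated at 21 mg/kg, with a range from 9 mg/kg to 50 mg/kg.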

Compound 4, dose for half-maximal effect: 56 mg/kg
The estimate for compound 4 lay 2.7-fold (0.43 log units) below the measured number; measured number outside the range, above it.
By their numbers in this assay, from the lowest: compounds 1, 2, 3 and 4 (each within the scatter of the next, the first and the last beyond it).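

In this assay, the change on the carbonyl carbon gives a 2.7-fold higher number from compound 1 to compound 4 (0.43 log units; beyond the scatter), the first step among these compounds to go beyond the scatter. The three earlier steps, all on the saturated chain carbon bound to the carbonyl carbon, stayed within it, so this position responds to (2-(diethylamino)ethyl)amino in place of ethoxy in a way those steps could not show. No evidence here explains this shift. The compounds shown leave open whether a simple methylamino on the same carbonyl carbon would move the number as far, or whether the diethylamino end of the chain is needed.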